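A few compounds are considered here, and "the series" means these few. Any claim that something is new, unique, unknown or untested is made for them only; others in the source may bear on it.

Compound 1 `CC1(C)[C@@H]2CC[C@@]1(C)[C@H](NC(=O)[C@@H](O)Cc1ccccc1)C2`, compound 2 `CC(C)C[C@H](O)C(=O)N[C@@H]1C[C@H]2CC[C@]1(C)C2(C)C` and compound 3 `CC(C)[C@H](O)C(=O)N[C@@H]1C[C@H]2CC[C@]1(C)C2(C)C` share one core and differ only on the saturated chain carbon bound to the carbonyl carbon and to the oxygen on a saturated carbon. In an ADME assay on HEK-293T cells (Homo sapiens) for cytotoxicity (a lower number here means a stronger inhibitor, a higher number a weaker inhibitor), compound 1 gives 52800 nM. In this assay compound 2 gives 112000 nM. For compound 3, this assay reports only a limit, > 200000 nM, so compound 3 stands at the edge of what the assay shows (the limit of > 200000 nM in this assay, at which 1 of the 3 values shown sits). The measured steps read a 2.1-fold higher number from compound 1 to compound 2 (0.33 log units; beyond the scatter), an at least 3.7-fold higher number from compound 1 to compound 3 (0.57 log units; beyond the scatter) and an at least 1.7-fold higher number from compound 2 to compound 3 (0.25 log units; that floor lies within the scatter). Compound 4 `CSCC[C@H](O)C(=O)N[C@@H]1C[C@H]2CC[C@]1(C)C2(C)C` is still to be measured; it differs from compound 3 by 2-(methylsulfanyl)ethyl in place of isopropyl on a saturated chain carbon bound to a carbonyl carbon and an oxygen on a saturated carbon. The two steps ending in compound 3 both replaced a benzyl or isobutyl with isopropyl and both raised the number, so the reverse direction, isopropyl to 2-(methylsulfanyl)ethyl, is expected to bring the number back down, by a step of roughly an at least 1.6-fold lower number from compound 3 to compound 4 (0.22 log units; that floor lies within the scatter). Compound 4 is therefore estimated at 120000 nM, with a range from 50000 nM to 250000 nM.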

Compound 4, half-maximal inhibitory concentration: 172000 nM
Compound 4: the middle estimate sits 1.4-fold (0.16 log units) below what was measured; the range from low to high includes it.
By their numbers in this assay, from the lowest: compound 1; then compounds 2 and 4 (each within the scatter of the next). At a limit, above all of these: compound 3.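

In this assay compound 3 gives only a limit, > 200000 nM. That leaves only a floor, an at least 1.1-fold lower number from compound 3 to compound 4 (0.06 log units; that floor lies within the scatter), so the size of this step cannot be read: the limit of > 200000 nM in this assay, at which 1 of the 4 values shown sits. With (methylsulfanyl)methyl in place of isopropyl on a saturated chain carbon, two bonds along the chain from a carbonyl carbon and an oxygen on a saturated carbon, the two compounds cannot be told apart, with a 1.5-fold higher number from compound 2 to compound 4 (0.19 log units; within the scatter). The benzyl group stays clearly apart from the 2-(methylsulfanyl)ethyl chain as well, with a 3.3-fold higher number from compound 1 to compound 4 (0.51 log units; beyond the scatter), and among the compounds with a measured number it alone stands apart from the others.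

The compounds shown leave open whether that separation belongs to the phenyl ring itself, which a cyclohexylmethyl group at this place would test. They also leave open how a chain ending in an amine or a carboxylic acid would read in this assay.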